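The source may hold more compounds than are shown below. What is called first, only, known or untested is meant among the compounds shown, and "the series" means these compounds.

Values measured in a physicochemical assay for lipophilicity, at pH 7.4; on this read-out higher numbers stand for higher lipophilicity and lower numbers for lower lipophilicity:
- compound 1 `Cc1cc(C)c(CN2CCc3ccc(O[C@@H]4CCOC4)c(Cl)c3C2=O)c(=O)[nH]1`: 1.5
- compound 2 `Cc1cc(C)c(CN2CCc3c(F)cc(O[C@@H]4CCOC4)c(Cl)c3C2=O)c(=O)[nH]1`: 2.1
- compound 3 `Cc1cc(C)c(CNC(=O)c2cccc(OC(C)C)c2C)c(=O)[nH]1`: 2.1

Compound 3, at 2.1, stands level with compound 2, and the two together hold the highest number of the three. Compound 1 lies lower, at 1.5.

The next compound, compound 4 `Cc1cc(C)c(CNC(=O)c2cccc(OC(C)C)c2Cl)c(=O)[nH]1`, keeps everything in compound 3 except one group, with chloro in place of methyl on an aromatic carbon.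

Within the data shown here, no measured pair makes this exchange. Among the measured compounds shown here, the only measured step is a number 0.60 log units higher from compound 1 to compound 2 (beyond the scatter), which is a modest one. It has fluoro in place of hydrogen on an aromatic carbon, on a different core, so it bears on the present change only loosely and sets a rough scale. A smaller step is therefore expected here in this assay, slightly upward if it shows at all. The expected step is a number 0.10 log units higher from compound 3 to compound 4 (within the scatter), which would not clear the scatter.

The estimate for compound 4 is 2.2, with an expected range from 1.8 to 2.6.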

Compound 4, distribution coefficient: 2
Compound 4: the middle estimate sits 0.20 log units above what was measured, within the range that was stated.
By their numbers in this assay, from the lowest: compound 1; then compounds 4, 2 and 3 (each within the scatter of the next).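

In this assay the change of chloro in place of methyl, on an aromatic carbon ortho to an isopropoxy group, gives a number 0.10 log units lower from compound 3 to compound 4 (within the scatter) and so leaves the two groups indistinguishable at this position. Among these compounds, the other measured step is a number 0.60 log units higher from compound 1 to compound 2 (beyond the scatter) with fluoro in place of hydrogen on a different core, so only this pair speaks to the exchange at this position. Nothing measured here addresses why methyl and chloro read alike at this place.

The compounds shown leave open whether the same exchange would read alike on the core of compound 1. They also leave open how a bromo or a nitrile would read at this position, and whether an amine in place of the isopropoxy group would shift the number.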